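The source may report more compounds than this note shows. Statements on the series, on what has been measured and on what is new or still open speak of the compounds shown alone.

Measured compounds:
- compound 1 `Cc1ccccc1NC(=S)N/N=C/c1ccc2ccccc2n1`: > 100000 nM
- compound 2 `Cc1csc2sc(/C=N/NC(N)=S)c(C)c12`: 1120 nM
- compound 3 `CN(C)C(=S)N/N=C/c1ccc2cccnc2n1`: 970 nM

These three compounds were tested in a functional assay on HeLa cells (Homo sapiens) for antiproliferative activity, read by sulforhodamine B assay, with a stated time of 72 h; a higher number here means a weaker inhibitor, a lower number a stronger inhibitor. Compound 2 gives 1120 nM and compound 3 gives 970 nM in this assay, two values that lie within the usual scatter of each other, so no order between them can be read. Compound 1 stands apart: in this assay compound 1 reports only a limit, > 100000 nM, not a number. This is the one value that sits at the limit (the limit of > 100000 nM in this assay, at which 1 of the 3 values shown sits), meaning that compound 1 is the weakest of the three shown.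

Compound 4 `Fc1ccc(NC(=S)N/N=C/c2ccc3ccccc3n2)cc1` has not yet been measured. It differs from compound 1 in one place: 4-fluorophenyl in place of 2-methylphenyl on an amide-type nitrogen. Within the data shown here, no pair of measured compounds shows what this kind of swap does, so the expected size of the step rests only on the starting point. Compound 4 keeps the rest of compound 1 unchanged, and compound 1 sits at the limit of this assay, so compound 4 is expected to remain weak, with a step from compound 1 that is expected to be small, around an at least 1.2-fold lower number from compound 1 to compound 4 (0.09 log units; that floor lies within the scatter). Compound 4 is therefore estimated at 80000 nM, within a range from 15000 nM to 300000 nM, and a further limit reading is quite possible.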

Compound 4, half-maximal inhibitory concentration: 33200 nM
Compound 4: the middle estimate sits 2.4-fold (0.38 log units) above what was measured; the measured number falls inside the stated range.
By their numbers in this assay, from the lowest: compounds 3 and 2 (each within the scatter of the next); then compound 4. At a limit, above all of these: compound 1.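

Putting 4-fluorophenyl in place of 2-methylphenyl on an amide-type nitrogen gives an at least 3.0-fold lower number from compound 1 to compound 4 (0.47 log units; beyond the scatter) in this assay, so this is the first swap shown in which changing one group, with the rest of the molecule kept, gives a real reading. Both groups hold 7 heavy atoms and one six-membered aromatic ring of carbon only, so the number moves even though those counts stay the same. The true size of the step stays unknown because compound 1 reports only a limit and not a number: the limit of > 100000 nM in this assay, at which 1 of the 4 values shown sits.

The swap changes two things at once, the kind of group on the phenyl ring and the number that marks its place, so the compounds shown cannot say which of the two goes with the lower number; a 2-fluorophenyl or a 4-methylphenyl group on the same nitrogen would pull them apart. As far as these compounds go, it also remains open how far this position can go, for instance with a plain phenyl, a 4-methoxyphenyl or a 4-aminophenyl group in the same place.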